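Thiophene in place of cyanophenyl in the acrylic acid series

The compounds below may be only part of what the source reports. "The series", "measured", "known", "first", "only" and "open" are said of these compounds alone.

Two compounds of the series have numbers in a functional assay on MCF7 cells (Homo sapiens) for cytotoxicity, read by CellTiter-Glo, with a stated time of 5 days; a higher number here means a weaker inhibitor, a lower number a stronger inhibitor. Compound 1 `CC/C(=C(/c1ccc(/C=C/C(=O)O)c(C)c1)c1ccc2[nH]ncc2c1)c1ccccc1` gives 14 nM. Compound 2 `CC/C(=C(/c1ccc(/C=C/C(=O)O)cc1)c1ccc2[nH]ncc2c1)c1ccc(C#N)cc1` gives 47 nM, the higher of the two numbers, and the gap to compound 1 lies beyond the scatter. Among the compounds with values here, no pair of measured compounds differs in only one place, so no single-point step is read directly from the data. Compound 3 `CC/C(=C(/c1ccc(/C=C/C(=O)O)cc1)c1ccc2[nH]ncc2c1)c1cscc1C` is not yet measured in this assay. It differs from compound 2 in one place: 4-methylthiophen-3-yl in place of 4-cyanophenyl on a double-bonded chain carbon bound to a double-bonded chain carbon and a saturated chain carbon. Within the data shown here, with no comparable step among the measured compounds, the size of this change is not anchored, and the step is expected to be none beyond the scatter, a 1.2-fold lower number from compound 2 to compound 3 (0.07 log units; within the scatter). Compound 3 is therefore estimated at 40 nM, with a range from 12 nM to 130 nM, pending the measurement.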

Compound 3, half-maximal inhibitory concentration: 2 nM
Beside the measured number, compound 3's estimate is 20-fold (1.30 log units) above it; the measured number lies below the stated range.
By their numbers in this assay, from the lowest: compound 3; then compound 1; then compound 2.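

In this assay, the place on a double-bonded chain carbon bound to a double-bonded chain carbon and a saturated chain carbon proves sensitive to the group it carries: 4-methylthiophen-3-yl in place of 4-cyanophenyl gives a 24-fold lower number from compound 2 to compound 3 (1.37 log units; beyond the scatter). Within the data shown here, this is the first single-place step, and it shows that a six-membered aromatic ring of carbon only is not required at this place for a low number, since a five-membered aromatic ring with fewer heavy atoms serves there. Nothing on hand accounts for the size of this step.

Among these compounds, the one step changes ring, methyl and nitrile together, so their shares cannot be separated. A thiophen-3-yl without the methyl, or a 2-methylphenyl, at this place would begin to divide them.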